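A Smaller Diamine Ring on the Terminal Amide

The source may report more compounds than this note shows. Statements on the series, on what has been measured and on what is new or still open speak of the compounds shown alone.

Compound 3 `CCN(CC)C1CCN(C(=O)CCCOc2cc(C(=O)N3CCCCc4sccc43)ccc2NC(=O)c2ccccc2-c2ccccc2)CC1` gives 9 nM in an assay on CHO cells for inhibition of Vasopressin V2 receptor (Homo sapiens), read by radioligand binding; on this read-out higher numbers stand for weaker inhibition and lower numbers for stronger inhibition. Its number is the second highest of the three measured: compound 1 `CN(C)C1CCN(C(=O)COc2cc(C(=O)N3CCCCc4sccc43)ccc2NC(=O)c2ccccc2-c2ccccc2)CC1` gives 8 nM, within the scatter of compound 3, while compound 2 `O=C(Nc1ccc(C(=O)N2CCCCc3sccc32)cc1OCCCC(=O)N1CCC(N2CCCCC2)CC1)c1ccccc1-c1ccccc1` gives 30 nM. Going by the values given here, the one measured step at a single site, a 3.3-fold lower number from compound 2 to compound 3 (0.52 log units; beyond the scatter), shows that exchanging the amine carried on the terminal amide carbonyl shifts the number modestly and no more.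

Compound 4 `CN1CCCN(C(=O)CCCOc2cc(C(=O)N3CCCCc4sccc43)ccc2NC(=O)c2ccccc2-c2ccccc2)CC1` carries 4-methyl-1,4-diazepan-1-yl in place of 4-(diethylamino)piperidin-1-yl on a carbonyl carbon. Among the compounds with values here, no measured step describes a change of ring size at this position, so the bearing of a 3.3-fold lower number from compound 2 to compound 3 (0.52 log units; beyond the scatter) is indirect: it shows only that a different tertiary amine in this region of the molecule gave a modest change. The step in this assay from compound 3 to compound 4 is therefore expected to be small, a 1.7-fold higher number from compound 3 to compound 4 (0.22 log units; within the scatter), within or only just beyond the scatter, and its direction cannot be read from the measured steps. Compound 4 is estimated at 15 nM, with a range from 5 nM to 45 nM.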

Compound 4, half-maximal inhibitory concentration: 10 nM
Compound 4: the middle estimate sits 1.5-fold (0.18 log units) above what was measured, within the range that was stated.
By their numbers in this assay, from the lowest: compounds 1, 3 and 4 (each within the scatter of the next); then compound 2.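

In this assay, going by these compounds alone, the exchange on the carbonyl carbon gives a 1.1-fold higher number from compound 3 to compound 4 (0.05 log units; within the scatter) and so adds something the earlier compounds did not show: this position accepts a seven-membered ring with two hetero atoms and fewer heavy atoms than 4-(diethylamino)piperidin-1-yl without a shift beyond the scatter. The same group gives a 3.0-fold lower number from compound 2 to compound 4 (0.48 log units; beyond the scatter) and thereby matches the step already seen with diethylamino, which leaves compound 2 apart from the other three. A further comparison, a 1.3-fold higher number from compound 1 to compound 4 (0.10 log units; within the scatter) with the saturated chain changed as well, also stays within the scatter.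

Going by these compounds, whether a primary amine, a morpholine ring or a carboxylic acid on this carbonyl carbon would keep the number in the same range remains open. No measurement at hand accounts for how these different amines come to give such similar numbers.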